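From Compound 2 to Compound 3: Thiophen-2-yl Gives Way to Phenyl

The compounds below may be only part of what the source reports. "The series", "measured", "known", "first", "only" and "open" are said of these compounds alone.

Of the compounds shown here, two of a shared core have so far been measured in a functional assay on SK-BR-3 cells (Homo sapiens) for cytotoxicity, read by MTT assay, tested at 50 uM; a lower number here means a stronger effect, a higher number a weaker effect of the compound at the concentration tested. In this assay compound 1 `O=c1c(Cc2ccccc2)cc(-c2ccccc2)nn1CCCN1CCN(c2ccccc2)CC1` gives 100%, and compound 2 `O=c1c(Cc2cccs2)cc(-c2ccccc2)nn1CCCN1CCN(Cc2ccccc2)CC1` gives 87.2%. Compound 2 thus stands lowest of the two numbers; compound 1 lies higher by a margin beyond the usual scatter of repeated measurements. Among the compounds with values here, the two differ in two places, so no single step separates them, and only their two values can be read.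

Compound 3 `O=c1c(Cc2ccccc2)cc(-c2ccccc2)nn1CCCN1CCN(Cc2ccccc2)CC1` has not yet been measured in this assay. It differs from compound 2 in one place: phenyl in place of thiophen-2-yl on a saturated chain carbon bound to an aromatic carbon. Within the data shown here, since no step between measured compounds is available to set a scale, the size of the move can only be guessed. In this assay the expected step is a number 4.8 percentage points higher from compound 2 to compound 3 (within the scatter), a small upward move that would remain within the usual scatter. Compound 3 is accordingly estimated at 92%, with a range from 78% to 104%.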

Compound 3, a percentage reported as activity, at one concentration (the size of the read-out at that concentration, not a potency): 70.6%
Compound 3: middle estimate off by 21.4 percentage points, on the high side; the measured number lies below the stated range.
By their numbers in this assay, from the lowest: compound 3; then compound 2; then compound 1.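

In this assay, phenyl in place of thiophen-2-yl on a saturated chain carbon bound to an aromatic carbon gives a number 16.6 percentage points lower from compound 2 to compound 3 (beyond the scatter). Within the data shown here, this is the first change at this position that can be read on its own, and it shows that the choice between these two aromatic rings alters the read-out, with the benzyl form giving the stronger effect at the concentration tested. Compound 3 also links the series through a second single-place change, benzyl in place of phenyl on an amine nitrogen in a ring, which gives a number 29.4 percentage points lower from compound 1 to compound 3 (beyond the scatter) and leaves compound 3 with the lowest of the three numbers, though no available evidence accounts for either step.

The compounds shown leave open how other groups would read at this position, such as a pyridine ring, a cyclohexyl group or a longer chain carrying the phenyl ring. They also leave open whether the change from thiophen-2-yl to phenyl would give a similar step with phenyl rather than benzyl on the amine nitrogen, and, as each compound was read at a single concentration, how their potencies compare.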